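The compounds below may be only part of what the source reports. "The series", "measured", "known", "first", "only" and "open" are said of these compounds alone.

Measured compounds:
Compound 1, `COc1ccc(/C=C/C(=O)CC(C)=O)cc1OC`: 8200 nM
Compound 2, `COc1cc(/C=C/c2cc(C)no2)ccc1O`: 28900 nM
Compound 3, `Cc1cc(/C=C/c2ccc(O)cc2)on1`: 67200 nM

In a functional assay on DU-145 cells (Homo sapiens) for cytotoxicity, read by MTT assay, with a stated time of 72 h (a higher number here means a weaker inhibitor, a lower number a stronger inhibitor), compound 3 gives the highest number of the three. Within the data shown here, its nearest neighbour is compound 2, and the step of a 2.3-fold higher number from compound 2 to compound 3 (0.37 log units; beyond the scatter) is the one measured change that bears directly on the position in question: removing the methoxy that sits on the ring carrying the hydroxy weakens the compound by a modest but real margin. Among the measured compounds shown here, compound 1 is further away still, with no single-point step connecting it to compound 3.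

Compound 4, `Cc1cc(/C=C/c2ccc(O)c(O)c2)on1`, is not yet measured. It differs from compound 3 in one place: hydroxy in place of hydrogen on an aromatic carbon, on an aromatic carbon of a six-membered aromatic ring of carbon only, ortho to a hydroxy group. A hydrogen-bond donor and acceptor enter where compound 3 has none.

The step of a 2.3-fold higher number from compound 2 to compound 3 (0.37 log units; beyond the scatter) shows that losing an oxygen-bearing substituent at a comparable place costs potency, so an oxygen-bearing group entering there is expected to recover part of that loss. For the measured compounds named here, no measured compound carries a second hydroxy, so the size is uncertain. Compound 4 is therefore expected to give 35000 nM in this assay, within 12000 nM to 100000 nM, the expected step being a 1.9-fold lower number from compound 3 to compound 4 (0.28 log units; within the scatter).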

Compound 4, half-maximal inhibitory concentration: 10500 nM
Estimate against measurement, compound 4: 3.3-fold (0.52 log units) above; the whole stated range lies above it.
By their numbers in this assay, from the lowest: compounds 1 and 4 (each within the scatter of the next); then compound 2; then compound 3.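

In this assay, among these compounds, the place ortho to a hydroxy group proves more responsive than the earlier compounds could show: hydroxy in place of hydrogen there gives a 6.4-fold lower number from compound 3 to compound 4 (0.81 log units; beyond the scatter) and so moves the compound well past the recovery that the methoxy comparison alone suggested. The nature of the oxygen-bearing group also matters, which compound 2 and compound 3 could not reveal on their own: hydrogen in place of methyl on that oxygen gives a 2.8-fold lower number from compound 2 to compound 4 (0.44 log units; beyond the scatter), so at this place the hydroxy compound 4 gives a lower number than the methoxy compound 2, and both give lower numbers than the unsubstituted compound 3, with every one of these steps beyond the scatter. Nothing shown here measures any property that would account for this order.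

As far as these compounds go, whether an amine or a fluorine at this same place would act as the hydroxy does remains open, as does whether an ethoxy would behave like the methoxy. From the compounds shown here alone, it is also open whether the gain depends on the hydroxy that the new group sits ortho to, since all three compounds in this comparison carry that hydroxy.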